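Swapping the amide ring in a thyroid receptor antagonist series

A few compounds are considered here, and "the series" means these few. Any claim that something is new, unique, unknown or untested is made for them only; others in the source may bear on it.

Compound 1 `CC1(C)CC2CC(C)(CN2C(=O)c2sc(-c3ccc(S(C)(=O)=O)c([N+](=O)[O-])c3)nc2C(F)(F)F)C1` carries a two-ring non-aromatic amine on the carbonyl carbon of the shared core; in a functional assay for antagonist activity at thyroid hormone receptor alpha (Homo sapiens), read by fluorescence polarization (a lower number here means a stronger inhibitor, a higher number a weaker inhibitor), compound 1 gives 430 nM. Compound 2 `CN(Cc1cccc(F)c1)C(=O)c1sc(-c2ccc(S(C)(=O)=O)c([N+](=O)[O-])c2)nc1C(F)(F)F` gives 1000 nM, and compound 3 `CC1Cc2ccccc2N1C(=O)c1sc(-c2ccc(S(C)(=O)=O)c([N+](=O)[O-])c2)nc1C(F)(F)F` gives 1100 nM, the highest of the three numbers. The step of a 2.3-fold higher number from compound 1 to compound 2 (0.37 log units; beyond the scatter) and the step of a 2.6-fold higher number from compound 1 to compound 3 (0.41 log units; beyond the scatter) were both modest, while the step of a 1.1-fold higher number from compound 2 to compound 3 (0.04 log units; within the scatter) stayed within the scatter. Compound 4 `CC1CCN(C(=O)c2sc(-c3ccc(S(C)(=O)=O)c([N+](=O)[O-])c3)nc2C(F)(F)F)CC1` differs from compound 3 in one place: 4-methylpiperidin-1-yl in place of 2-methyl-2,3-dihydro-1H-indol-1-yl on a carbonyl carbon. The entering group is a non-aromatic ring, as in compound 1, but smaller, so a small drop in the number, or none beyond the scatter, is expected: a 1.6-fold lower number from compound 3 to compound 4 (0.20 log units; within the scatter). Compound 4 is therefore estimated at 700 nM, with a range from 300 nM to 1600 nM.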

Compound 4, half-maximal inhibitory concentration: 190 nM
Compound 4: middle estimate off by 3.7-fold (0.57 log units), on the high side; the measured number lies below the stated range.
By their numbers in this assay, from the lowest: compound 4; then compound 1; then compounds 2 and 3 (each within the scatter of the next).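

In this assay, placing 4-methylpiperidin-1-yl on the carbonyl carbon gives a 5.8-fold lower number from compound 3 to compound 4 (0.76 log units; beyond the scatter) and a 5.3-fold lower number from compound 2 to compound 4 (0.72 log units; beyond the scatter), so among these compounds, the groups carrying an aromatic ring sit at the weak end. The step against another non-aromatic group, a 2.3-fold lower number from compound 1 to compound 4 (0.35 log units; beyond the scatter), makes compound 4 the strongest inhibitor of the four, with fewer heavy atoms in its group than compound 1 has. Nothing shown explains this difference. Going by these compounds, whether the methyl group matters remains open, as does how piperidin-1-yl without it, or morpholin-4-yl, would compare.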